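The source may report more compounds than this note shows. Statements on the series, on what has been measured and on what is new or still open speak of the compounds shown alone.

Measured in a functional assay on PC-3 cells (Homo sapiens) for inhibition, read by sulforhodamine B assay, with a stated time of 48 h, tested at 50 uM; a higher number here means more inhibition of growth at the concentration tested, a lower number less inhibition of growth:
- compound 1 `COc1ccc([C@@H]2C/C(=N/OCc3cn(-c4ccc(O)cc4)nn3)c3cc(CC=C(C)C)c(OC)cc3O2)cc1`: 64%
- compound 2 `COc1ccc([C@@H]2C/C(=N/OCc3cn(-c4ccc(C#N)cc4)nn3)c3cc(CC=C(C)C)c(OC)cc3O2)cc1`: 50%
- compound 3 `COc1ccc([C@@H]2C/C(=N/OCc3cn(-c4cc(OC)c(OC)c(OC)c4)nn3)c3cc(CC=C(C)C)c(OC)cc3O2)cc1`: 36%

Compound 2 holds the middle place of the three. Above it lies a number 14 percentage points lower from compound 1 to compound 2 (beyond the scatter), and below it lies a number 14 percentage points lower from compound 2 to compound 3 (beyond the scatter).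

Compound 4 `COc1ccc([C@@H]2C/C(=N/OCc3cn(-c4ccc(NC(=O)c5ccccc5)cc4)nn3)c3cc(CC=C(C)C)c(OC)cc3O2)cc1` is the next case, with benzamido in place of cyano on an aromatic carbon, para to a large group: benzamido in place of cyano on an aromatic carbon.

Among the compounds with values here, no measured compound carries benzamido, so the guidance is indirect. The closest swap of one group on this aromatic carbon is a number 14 percentage points lower from compound 1 to compound 2 (beyond the scatter). The two changes of the whole aryl group are a number 28 percentage points lower from compound 1 to compound 3 (beyond the scatter) and a number 14 percentage points lower from compound 2 to compound 3 (beyond the scatter). Within the data shown here, all three steps are modest, and the lowest value so far belongs to compound 3 with 36%, the one with the largest aryl group among the three. A modest step downward is therefore expected, though this rests on thin evidence.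

The expected change is a number 12 percentage points lower from compound 2 to compound 4 (beyond the scatter).

The estimate for compound 4 is 38%, with an expected range from 18% to 58%.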

Compound 4, percent growth inhibition at one concentration: 22%
Estimate against measurement, compound 4: 16 percentage points above, and the stated range covers the measured number.
By their numbers in this assay, from the lowest: compound 4; then compound 3; then compound 2; then compound 1.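

In this assay, within the data shown here, benzamido in place of cyano on this aromatic carbon, para to a large group, gives a number 28 percentage points lower from compound 2 to compound 4 (beyond the scatter) and benzamido in place of hydroxy gives a number 42 percentage points lower from compound 1 to compound 4 (beyond the scatter) as the only large step printed for the series. Until now this place had shown only hydroxy and cyano, and the new result adds a group with an amide hydrogen and a further six-membered aromatic ring, with compound 4 at 22% in this assay. Nothing on hand explains the fall in the number.

Open, as far as these compounds go, is whether an amine or an acetamido group on this carbon would stand nearer to compound 1 or to compound 4. Also open, from the compounds shown here alone, is whether a plain phenyl group, with no amide link, would give a similar number.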